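A few compounds are considered here, and "the series" means these few. Any claim that something is new, unique, unknown or untested is made for them only; others in the source may bear on it.

The measured compounds:
Compound 1, `O=C(Nc1ccnnc1)c1cc(N2C[C@H]3COC[C@H]3C2)ccc1OCc1ccccc1`: 57000 nM
Compound 2, `O=C(Nc1ccnnc1)c1cc(N2CCCCC2)ccc1OCc1ccccc1`: 60000 nM
Compound 3, `C[C@@H]1CN(c2ccc(OCc3ccccc3)c(C(=O)Nc3ccnnc3)c2)C[C@H](C)O1`: 29000 nM

In a physicochemical assay for solubility, measured as kinetic solubility (on this read-out lower numbers stand for lower solubility and higher numbers for higher solubility), compound 2 holds the highest of the three numbers. Compound 1 cannot be told apart from it, since the step of a 1.1-fold higher number from compound 1 to compound 2 (0.02 log units; within the scatter) stays within the scatter, whereas compound 3 sits clearly apart, as the step of a 2.1-fold lower number from compound 2 to compound 3 (0.32 log units; beyond the scatter) shows.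

Compound 4, `O=C(Nc1ccnnc1)c1cc(N2CCC(CO)CC2)ccc1OCc1ccccc1`, is not yet measured. It differs from compound 2 in one place: hydroxymethyl in place of hydrogen on a saturated ring carbon. Among the measured compounds shown here, two measured steps touch the same ring carried on the shared core. The step of a 1.1-fold higher number from compound 1 to compound 2 (0.02 log units; within the scatter) exchanged one whole ring system for another with no change beyond the scatter. The step of a 2.1-fold lower number from compound 2 to compound 3 (0.32 log units; beyond the scatter) exchanged piperidin-1-yl for 2,6-dimethylmorpholin-4-yl and gave a modest fall. For the measured compounds named here, neither step adds a hydroxymethyl to a ring carbon, so no measured pair speaks directly to this change; the two steps only show that altering this ring moves the number little or modestly.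

The step of a 1.2-fold higher number from compound 2 to compound 4 (0.07 log units; within the scatter) is therefore expected to stay within the scatter, leaning if anything toward a higher number. Compound 4 is estimated at 70000 nM, within a range from 30000 nM to 160000 nM.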

Compound 4, solubility: 323000 nM
For compound 4 the middle estimate is 4.6-fold (0.66 log units) below the measured one, and the stated range ends below it.
By their numbers in this assay, from the lowest: compounds 3, 1 and 2 (each within the scatter of the next, the first and the last beyond it); then compound 4.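

In this assay, putting hydroxymethyl in place of hydrogen on a saturated ring carbon, three ring bonds from the ring nitrogen, gives a 5.4-fold higher number from compound 2 to compound 4 (0.73 log units; beyond the scatter). This small addition moves the number further than either earlier change involving compound 2, which replaced the whole ring group: a 1.1-fold higher number from compound 1 to compound 2 (0.02 log units; within the scatter) and a 2.1-fold lower number from compound 2 to compound 3 (0.32 log units; beyond the scatter), so this ring carbon is a place where one added group can matter more than swapping the ring. The ring group of compound 4 also stands beyond the scatter from the other two ring groups, with a 5.7-fold higher number from compound 1 to compound 4 (0.75 log units; beyond the scatter) and an 11-fold higher number from compound 3 to compound 4 (1.05 log units; beyond the scatter), although these steps replace whole groups and do not isolate hydroxymethyl. No measurement here offers an explanation for the size of this step.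

From the compounds shown here alone, with a single group at a single ring carbon, it remains open whether methoxymethyl, a longer chain such as 2-hydroxyethyl, an amine or a carboxylic acid at the same place would give a similar number. Going by these compounds, it is equally open whether hydroxymethyl would give a step of this size on the ring of compound 1 or compound 3.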